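A Second Methoxy Group on the Shared Core

The source may hold more compounds than are shown below. What is called first, only, known or untested is meant among the compounds shown, and "the series" means these compounds.

Compound 1 `COc1ccc(-c2nnc(SC/C(=N/O)c3ccccc3)n2-c2ccccc2)cc1` is the starting point. In a functional assay on the whole organism (strain albino) for inhibition, with Rattus norvegicus as the target, read by paw edema, with a stated time of 1 h, at a dose of 0.28 mmol/kg by the oral route (on this read-out lower numbers stand for less inhibition and higher numbers for more inhibition at the one dose given (going by the name of the read-out)), compound 1 gives 58%. Among the measured compounds shown here, its one measured neighbour, compound 2 `C=CCn1c(SC/C(=N/O)c2ccccc2)nnc1-c1ccc(OC)cc1`, gives 61% in this assay. For the measured compounds named here, the only step measured so far, a number 3 percentage points higher from compound 1 to compound 2 (within the scatter), changes the group on the aromatic nitrogen and lies within the usual scatter, so the two numbers cannot be told apart, and compound 1 stands alongside compound 2 rather than apart from it.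

The next compound, compound 3 `COc1ccc(-c2nnc(SC/C(=N/O)c3ccccc3)n2-c2ccccc2)cc1OC`, differs from compound 1 at a different place: methoxy in place of hydrogen on an aromatic carbon, which turns a 4-methoxyphenyl into a 3,4-dimethoxyphenyl. Going by the values given here, no measured step touches that ring, and the single step that exists was small. There is therefore no ground to expect a step beyond the scatter in this assay, in either direction. Compound 3 is expected to give about 58%, between 45% and 70%. That estimate means a step of no change at the digits printed from compound 1 to compound 3 (within the scatter), expected to stay within the scatter.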

Compound 3, a percentage reported as inhibition, in the whole organism at one dose (the size of the read-out at that dose, not a potency): 55%
The estimate for compound 3 lay 3 percentage points above the measured number; the range from low to high includes it.
By their numbers in this assay, from the lowest: compounds 3, 1 and 2 (each within the scatter of the next).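

In this assay, turning 4-methoxyphenyl into 3,4-dimethoxyphenyl gives a number 3 percentage points lower from compound 1 to compound 3 (within the scatter). Among the compounds shown here, this is the first measured step on this ring, as the earlier step concerned the group on the aromatic nitrogen, and it shows that a methoxy group can stand on this aromatic carbon, ortho to a methoxy group and meta to a large group, with no difference that can be told from the scatter at this one dose. No measurement at hand gives a reason for this result.

The compounds shown leave open whether an amine, a carboxylic acid or a longer chain at this position would give a step beyond the scatter. They also leave open whether the added methoxy group would give a similar result with allyl in place of phenyl on the aromatic nitrogen, as in compound 2.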